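Permeability notes on the larger pyrazole substituent in compound 3

The compounds below may be only part of what the source reports. "The series", "measured", "known", "first", "only" and "open" are said of these compounds alone.

Among the compounds with values here, compound 2 `Cn1cc(-c2nc3c(-c4ccc5c(c4)CCC[C@H]5NC(=O)c4nc(C(C)(C)C)no4)ccnc3[nH]2)cn1` stands lowest of the two numbers so far in an ADME assay on Caco-2 cells (Homo sapiens) for permeability, in the apical to basolateral direction; a higher number here means that the compound crosses the layer faster, a lower number that the compound crosses the layer more slowly: compound 2 gives 1 10^-6 cm/s. Within the data shown here, its only neighbour is compound 1 `Cn1cc(-c2nc3c(-c4ccc5c(c4)CCC[C@@H]5NC(=O)c4nc(C(C)(C)C)no4)ccnc3[nH]2)cn1`, which in this assay gives 5 10^-6 cm/s; the step of a 5.0-fold lower number from compound 1 to compound 2 (0.70 log units; beyond the scatter) rests solely on (the fact that compounds 1 and 2 differ only in the configuration as drawn). Compound 3 `Cc1c(-c2nc3c(-c4ccc5c(c4)CCC[C@H]5NC(=O)c4nc(C(C)(C)C)no4)ccnc3[nH]2)cnn1C1CCOCC1` has not been measured. Relative to compound 2 the change is a group of 12 heavy atoms (9 carbon, 2 nitrogen, 1 oxygen; one five-membered aromatic ring with 2 hetero atoms, one six-membered non-aromatic ring with 1 hetero atom) in place of a group of 6 heavy atoms (4 carbon, 2 nitrogen; one five-membered aromatic ring with 2 hetero atoms), on an aromatic carbon. Among the measured compounds shown here, no measured step bears on this change: the single step from compound 1 to compound 2 alters configuration only and leaves the group on the aromatic carbon untouched, so it gives no guide to the size or direction of the step to compound 3. The expectation is therefore a step of undetermined direction, anchored on compound 2 with a wide range. For compound 3 the expected value in this assay is 1.5 10^-6 cm/s, between 0.4 10^-6 cm/s and 6 10^-6 cm/s. This corresponds to an expected step of a 1.5-fold higher number from compound 2 to compound 3 (0.18 log units; within the scatter).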

Compound 3, apparent permeability: 5 10^-6 cm/s
Compound 3: the middle estimate sits 3.3-fold (0.52 log units) below what was measured, within the range that was stated.
By their numbers in this assay, from the lowest: compound 2; then compounds 1 and 3 (each within the scatter of the next).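

The position on the aromatic carbon of the five-membered ring, part of the fused system, now has a measured effect in this assay: replacing 1-methyl-1H-pyrazol-4-yl with the larger group gives a 5.0-fold higher number from compound 2 to compound 3 (0.70 log units; beyond the scatter). The number therefore responds to a change at this position, and the group of 12 heavy atoms, with its six-membered non-aromatic ring, does not lower it. Nothing available accounts for this step.

As far as these compounds go, the whole group changes in one step, so the contribution of the six-membered non-aromatic ring cannot be separated from that of the rest of the entering group, and the same change in the configuration of compound 1 remains unknown. Also open, from the compounds shown here alone, is how the number would respond to an amine or a carboxylic acid on that ring.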